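The source may report more compounds than this note shows. Statements on the series, on what has been measured and on what is new or still open speak of the compounds shown alone.

Working notes on the series. Compound 2 `COc1ccccc1Oc1ccc2c(NCCCNCc3ccco3)ccnc2c1` is the reference point; in an ADME assay for permeability, using PAMPA, with a stated time of 30 min, at pH 7.4 (on this read-out lower numbers stand for lower permeability and higher numbers for higher permeability), compound 2 gives 317 10^-6 cm/s. Compound 1 `CCC(CC)c1ccc2c(NCCCNCc3ccco3)ccnc2c1` carries the change (pentan-3-yl in place of 2-methoxyphenoxy on an aromatic carbon); in this assay compound 1 gives 23 10^-6 cm/s, and the step is a 14-fold lower number from compound 2 to compound 1 (1.14 log units; beyond the scatter). Compound 3 `COc1ccccc1Oc1ccc2c(NCCCNCc3cccc(OC)c3O)ccnc2c1` differs from compound 2 in its core by 2-hydroxy-3-methoxyphenyl in place of furan-2-yl on a saturated chain carbon bound to an amine nitrogen; in this assay compound 3 gives 317 10^-6 cm/s, the step being no change at the digits printed from compound 2 to compound 3 (within the scatter). Compound 4 `CCC(CC)c1ccc2c(NCCCNCc3cccc(OC)c3O)ccnc2c1` is not yet measured. It differs from compound 3 by pentan-3-yl in place of 2-methoxyphenoxy on an aromatic carbon, the same change that takes compound 2 to compound 1, at a place described in the same words, here made on the core of compound 3. The change occurs twice among these four compounds, with one measured instance. The expectation for compound 4 rests on that instance alone. In this assay the expected step is a 14-fold lower number from compound 3 to compound 4 (1.14 log units; beyond the scatter), set beside the earlier 14-fold lower number from compound 2 to compound 1 (1.14 log units; beyond the scatter) because that step was a 14-fold lower number from compound 2 to compound 1 (1.14 log units; beyond the scatter) and the core change showed no change at the digits printed from compound 2 to compound 3 (within the scatter). Compound 4 is estimated at 23 10^-6 cm/s. The expected range for compound 4 runs from 9 10^-6 cm/s to 55 10^-6 cm/s.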

Compound 4, apparent permeability in the ADME assay: 23 10^-6 cm/s
Beside the measured number, compound 4's estimate shows no gap at the digits printed; low and high end bracket the measured number.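

In the ADME assay, pentan-3-yl in place of 2-methoxyphenoxy on an aromatic carbon gives a 14-fold lower number from compound 3 to compound 4 (1.14 log units; beyond the scatter), and the step carries over from the core of compound 2 to the core of compound 3: the same change on two cores in the ADME assay, a 14-fold lower number (1.14 log units; beyond the scatter) from compound 2 to compound 1 and a 14-fold lower number (1.14 log units; beyond the scatter) from compound 3 to compound 4, 1.0-fold (0.00 log units) apart, within the scatter of two such steps Read the other way, 2-hydroxy-3-methoxyphenyl in place of furan-2-yl gives no change at the digits printed from compound 1 to compound 4 (within the scatter), matching the same exchange with 2-methoxyphenoxy in place: the same change on two cores in the ADME assay, no change at the digits printed (within the scatter) from compound 2 to compound 3 and no change at the digits printed (within the scatter) from compound 1 to compound 4, 1.0-fold (0.00 log units) apart, within the scatter of two such steps This shows the change carrying over between these two cores only, and in a physicochemical assay for solubility, with a stated time of 18 h, at pH 7.4 (a lower number here means a less soluble compound, a higher number a more soluble compound), it has a single instance among the compounds shown, so its transfer between cores cannot be read there: the measured solubility of compound 3, 14500 nM, and of compound 4, 4200 nM, a 3.5-fold lower number (0.54 log units; beyond the scatter) In the physicochemical assay compound 3 gives 14500 nM and compound 4 gives 4200 nM for that single instance.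

The compounds shown leave open whether the match holds when an amine or a carboxylic acid takes the place of pentan-3-yl on that aromatic carbon. They also leave open whether it holds when a phenyl group without substituents takes the place of furan-2-yl or 2-hydroxy-3-methoxyphenyl.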